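The source may hold more compounds than are shown below. What is called first, only, known or untested is meant among the compounds shown, and "the series" means these compounds.

Measured so far: compound 1, `NC(=O)CC[C@H](NC(=O)CN(c1nc(Cl)nc2[nH]cnc12)C1CC1)C(=O)OCc1ccccc1`, with 31.1%; compound 2, `CC(C)C[C@H](NC(=O)CN(c1nc(Cl)nc2[nH]cnc12)C1CC1)C(=O)OCc1ccccc1`, with 5.26%; compound 3, `CC(C)C[C@H](NC(=O)CN(c1nc(Cl)nc2[nH]cnc12)C1CC1)C(=O)O`, with 9.13%.

All three were tested in a functional assay on the whole organism (Tail, strain ICR) with Mus musculus as the target, in the tail flick test, with a stated time of 150 min, at a dose of 25 umol/kg by the oral route; a lower number here means a weaker effect, a higher number a stronger effect of the compound at the dose given. Among the measured compounds shown here, the one structural change that mattered so far is carbamoylmethyl in place of isopropyl on a saturated chain carbon, two bonds along the chain from an amide-type nitrogen and a carbonyl carbon, which gave a number 25.8 percentage points higher from compound 2 to compound 1 (beyond the scatter). The other change, (hydrogen in place of benzyl on an oxygen next to a carbonyl group), gave a number 3.9 percentage points higher from compound 2 to compound 3 (within the scatter), so compound 2 and compound 3 cannot be told apart by this measurement.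

Compound 4, `NC(=O)CC[C@H](NC(=O)CN(c1nc(Cl)nc2[nH]cnc12)C1CC1)C(=O)O`, has not been measured yet. It differs from compound 3 by carbamoylmethyl in place of isopropyl on a saturated chain carbon, two bonds along the chain from an amide-type nitrogen and a carbonyl carbon, the same change that turned compound 2 into compound 1, and at the same place on the chain. The two cores on which this change is made differ from each other by hydrogen in place of benzyl on an oxygen next to a carbonyl group, a difference that by itself left the read-out essentially unchanged.

Compound 4 is therefore expected to gain roughly as much as the earlier pair did, an estimated step of a number 20.9 percentage points higher from compound 3 to compound 4 (beyond the scatter), because the same change gave a number 25.8 percentage points higher from compound 2 to compound 1 (beyond the scatter) while the change between the two cores gave only a number 3.9 percentage points higher from compound 2 to compound 3 (within the scatter). Compound 4 is estimated at 30%, with a likely range from 15% to 45%.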

Compound 4, a percentage reported as activity, at one dose (the size of the read-out at that dose, not a potency): 11.4%
For compound 4 the middle estimate is 18.6 percentage points above the measured one, and the stated range ends above it.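

In this assay, carbamoylmethyl in place of isopropyl did not carry over from the core bearing benzyl to the core bearing hydrogen in its place, giving only a number 2.3 percentage points higher from compound 3 to compound 4 (within the scatter): the same change on two cores in this assay, a number 25.8 percentage points higher (beyond the scatter) from compound 2 to compound 1 and a number 2.3 percentage points higher (within the scatter) from compound 3 to compound 4, 23.6 percentage points apart, beyond the scatter of two such steps Read the other way round, the same four compounds show that hydrogen in place of benzyl is not a neutral swap on every core, since it gives a number 19.7 percentage points lower from compound 1 to compound 4 (beyond the scatter) when carbamoylmethyl is present: the same change on two cores in this assay, a number 3.9 percentage points higher (within the scatter) from compound 2 to compound 3 and a number 19.7 percentage points lower (beyond the scatter) from compound 1 to compound 4, 23.6 percentage points apart, beyond the scatter of two such steps The two changes therefore do not simply add up in this series, and the gain from carbamoylmethyl cannot be assumed on a new core, but these four compounds do not show what lies behind this, and a single pair of cores gives no general rule.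

On these data alone, it remains open whether a methyl or ethyl group in place of benzyl would keep the gain seen with carbamoylmethyl. The same question applies to other chains in place of carbamoylmethyl, such as 2-carbamoylethyl or one ending in an amine.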